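From Methoxyethyl to Isopropyl on a Sulfonamide Nitrogen

The source may hold more compounds than are shown below. What is called first, only, known or untested is meant among the compounds shown, and "the series" means these compounds.

In an ADME assay on a cell-free system (plasma, Mus musculus) (on this read-out higher numbers stand for a larger free fraction and lower numbers for a smaller free fraction), compound 1 (`CCCS(=O)(=O)c1cccc(C#Cc2cc(Cl)ccc2OCC(=O)O)c1`) gives 0.024 and compound 2 (`COCCN(C)S(=O)(=O)c1ccc(C)c(C#Cc2cc(Cl)ccc2OCC(=O)O)c1`) gives 0.007 as the lower of the two numbers, by a gap beyond the usual scatter of repeated measurements. Compound 3 (`Cc1ccc(S(=O)(=O)N(C)C(C)C)cc1C#Cc1cc(Cl)ccc1OCC(=O)O`) differs from compound 2 in one place, with isopropyl in place of 2-methoxyethyl on a sulfonamide nitrogen. Among the measured compounds shown here, no measured pair shows this swap on its own, so the expectation simply starts from compound 2 and its 0.007 reading. In this assay no step beyond the scatter is expected, only a slight drift downward, and the expected change is a 1.2-fold lower number from compound 2 to compound 3 (0.07 log units; within the scatter) and no more than that. For compound 3 the estimated value is 0.006 and 0.003 to 0.013 is the expected range.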

Compound 3, unbound fraction: 0.005
Estimate against measurement, compound 3: 1.2-fold (0.08 log units) above; low and high end bracket the measured number.
By their numbers in this assay, from the lowest: compounds 3 and 2 (each within the scatter of the next); then compound 1.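

Among the compounds shown here, this is the first comparison that changes only one place, the group on the sulfonamide nitrogen, and in this assay it gives a 1.4-fold lower number from compound 2 to compound 3 (0.15 log units; within the scatter). Replacing 2-methoxyethyl, with 4 heavy atoms and 1 hydrogen-bond acceptor, by isopropyl, with 3 heavy atoms and 0 hydrogen-bond acceptors, therefore leaves compound 2 and compound 3 indistinguishable on this read-out. No supporting measurement is available to explain this result.

From the compounds shown here alone, whether a group such as 2-hydroxyethyl, a longer chain or an amine on this nitrogen would shift the free fraction beyond the scatter remains open. Compound 1 differs from compound 2 in more than one place, so the gap between them cannot be assigned to any single change.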